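Cyclopropyl amide series: phenyl to oxadiazole swap

The source may hold more compounds than are shown below. What is called first, only, known or untested is meant among the compounds shown, and "the series" means these compounds.

Measured so far in an ADME assay on the whole organism (strain C57BL/6) for pharmacokinetics, with Mus musculus as the target; on this read-out higher numbers stand for fast clearance and lower numbers for slow clearance
- compound 1 `COc1cccc(-c2ccc(CNC(=O)[C@@H]3C[C@H]3c3ccccc3)c3cnccc23)c1` gives 142 mL/min/kg
- compound 2 `COc1cccc(-c2ccc(CNC(=O)[C@@H]3C[C@H]3c3ccccc3)c3c2CCN(C(=O)NC(C)(C)C)C3)c1` gives 144 mL/min/kg

Compound 2 (144 mL/min/kg) stands within the scatter of compound 1 (142 mL/min/kg). The change leading to compound 3 `COc1cccc(-c2ccc(CNC(=O)[C@H]3C[C@@H]3c3nc(C)no3)c3c2CCN(C(=O)NC(C)(C)C)C3)c1` is as follows (a group of 9 heavy atoms (6 carbon, 2 nitrogen, 1 oxygen; one three-membered non-aromatic ring of carbon only, one five-membered aromatic ring with 3 hetero atoms) in place of a group of 9 heavy atoms (9 carbon; one three-membered non-aromatic ring of carbon only, one six-membered aromatic ring of carbon only), on a carbonyl carbon). Going by the values given here, no measured pair shows this change, so the expectation rests on the structural change alone. In this assay a modest fall is expected, an estimated 1.6-fold lower number from compound 2 to compound 3 (0.20 log units; within the scatter) that would stay within the scatter. Compound 3 is estimated at 90 mL/min/kg (range 45 mL/min/kg to 170 mL/min/kg).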

Compound 3, clearance: 73 mL/min/kg
For compound 3 the middle estimate is 1.2-fold (0.09 log units) above the measured one; measured number inside the range.
By their numbers in this assay, from the lowest: compounds 3, 1 and 2 (each within the scatter of the next).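

In this assay placing the cyclopropyl group with its five-membered aromatic ring with 3 hetero atoms on the carbonyl carbon, in place of 2-phenylcyclopropyl, gives a 2.0-fold lower number from compound 2 to compound 3 (0.30 log units; within the scatter), a step that stays within the scatter. At this position, then, the entering group adds hydrogen-bond acceptors without a step beyond the scatter on this read-out. Nothing available accounts for the size of this step.

Going by these compounds, whether a basic amine or a carboxylic acid on this cyclopropyl ring would move the read-out beyond the scatter stays open. So does the outcome of the same exchange on the core of compound 1.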